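The compounds below may be only part of what the source reports. "The series", "measured", "known", "first", "only" and "open" are said of these compounds alone.

Measured compounds:
compound 1 `COc1ccc(CNc2nc(-c3ccccc3C(F)(F)F)nc3ccccc23)cc1`, 6200 nM in an assay on a protein complex for inhibition of ubiquitin carboxyl-terminal hydrolase 1/WD repeat-containing protein 48 (Homo sapiens), read by fluorescence; on this read-out lower numbers stand for stronger inhibition and higher numbers for weaker inhibition
compound 2 `FC(F)(F)c1ccccc1-c1nc(NCc2ccc(-c3ccccc3)cc2)c2ccccc2n1`, 3700 nM
compound 3 `FC(F)(F)c1ccccc1-c1nc(NCc2ccc(-c3ccc(Cl)cc3)cc2)c2ccccc2n1`, 3600 nM

Compound 3 is not separable from the others on these numbers: the steps of a 1.7-fold lower number from compound 1 to compound 3 (0.24 log units; within the scatter) and a 1.0-fold lower number from compound 2 to compound 3 (0.01 log units; within the scatter) both stay within the scatter, as does a 1.7-fold lower number from compound 1 to compound 2 (0.22 log units; within the scatter). Compound 4 `FC(F)(F)c1ccccc1-c1nc(NCc2ccc(-c3cccc(Cl)c3)cc2)c2ccccc2n1` is obtained from compound 3 by 3-chlorophenyl in place of 4-chlorophenyl on an aromatic carbon. For the measured compounds named here, the only measured step that touches the chlorine is a 1.0-fold lower number from compound 2 to compound 3 (0.01 log units; within the scatter), which shows that adding the chlorine changed nothing beyond the scatter. Going by the values given here, nothing here tells how moving it would matter, so compound 4 is expected to sit within the scatter of compound 3, with no change at the digits printed from compound 3 to compound 4 (within the scatter) amounting to no real step. The estimate for compound 4 is therefore 3600 nM, in a range from 1800 nM to 7200 nM.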

Compound 4, half-maximal inhibitory concentration: 2700 nM
Compound 4: middle estimate off by 1.3-fold (0.12 log units), on the high side; the measured number falls inside the stated range.
By their numbers in this assay, from the lowest: compounds 4, 3, 2 and 1 (each within the scatter of the next, the first and the last beyond it).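

In this assay, 3-chlorophenyl in place of 4-chlorophenyl gives a 1.3-fold lower number from compound 3 to compound 4 (0.12 log units; within the scatter) and so changes nothing beyond the scatter, and the chloro in this new place likewise amounts only to a 1.4-fold lower number from compound 2 to compound 4 (0.14 log units; within the scatter) against the plain phenyl. The chlorine is therefore accepted in either of these two places on the ring. For the compounds shown here, measured against the methoxy, this is the first step to pass the scatter, with a 2.3-fold lower number from compound 1 to compound 4 (0.36 log units; beyond the scatter) as a modest gain.

From the compounds shown here alone, whether an amine or a carboxylic acid in place of the chlorine would move the number further remains open. Nothing given here bears on what lies behind these small steps.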